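Coumarin-triazole dienones: moving the methoxy group

The source may hold more compounds than are shown below. What is called first, only, known or untested is meant among the compounds shown, and "the series" means these compounds.

Measured so far in a functional assay on PC-3 cells (Homo sapiens) for inhibition, read by sulforhodamine B assay, with a stated time of 48 h, tested at 50 uM; on this read-out higher numbers stand for more inhibition of growth at the one concentration tested and lower numbers for less inhibition of growth:
compound 1 `COc1cc(/C=C/C(=O)/C=C/c2cc(OC)c(OC)c(OC)c2)ccc1OCc1cn(CCOc2cc(=O)oc3ccccc23)nn1` gives 22%
compound 2 `COc1ccc(/C=C/C(=O)/C=C/c2ccc(OCc3cn(CCOc4cc(=O)oc5ccccc45)nn3)c(OC)c2)cc1` gives 15%

Compound 2 holds the lowest of the two numbers; its nearest neighbour is compound 1, and the step of a number 7 percentage points lower from compound 1 to compound 2 (within the scatter) stays within the scatter. Compound 3 `COc1cccc(/C=C/C(=O)/C=C/c2ccc(OCc3cn(CCOc4cc(=O)oc5ccccc45)nn3)c(OC)c2)c1` is not yet measured. It differs from compound 2 by 3-methoxyphenyl in place of 4-methoxyphenyl on a double-bonded chain carbon bound to a double-bonded chain carbon. Among the measured compounds shown here, no measured step covers this particular change; the one step known concerns a different replacement. Compound 3 is therefore expected to show no step beyond the scatter in this assay, with a number 1 percentage points higher from compound 2 to compound 3 (within the scatter) as the expected movement. The estimate for compound 3 in this assay is 16%, within 4% to 30%.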

Compound 3, percent growth inhibition at one concentration: 13%
Beside the measured number, compound 3's estimate is 3 percentage points above it; measured number inside the range.
By their numbers in this assay, from the lowest: compounds 3, 2 and 1 (each within the scatter of the next).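

Moving the methoxy group, with 3-methoxyphenyl in place of 4-methoxyphenyl on a double-bonded chain carbon bound to a double-bonded chain carbon, gives in this assay a number 2 percentage points lower from compound 2 to compound 3 (within the scatter). With 3-methoxyphenyl in place of 3,4,5-trimethoxyphenyl at the same place, the result is a number 9 percentage points lower from compound 1 to compound 3 (within the scatter), so all three groups remain within the scatter of one another. No measured evidence bears on these small steps.

Still open, from the compounds shown here alone, is whether another group at this place, such as a dimethylamino group or a carboxylic acid, would give a step beyond the scatter. The compounds shown also leave open how the series reads at other concentrations.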